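The compounds below may be only part of what the source reports. "The series", "measured", "known", "first", "only" and "open" are said of these compounds alone.

Values in a functional assay on HCT-116 cells (Homo sapiens) for cytotoxicity, with a stated time of 48 h; a higher number here means a weaker inhibitor, a lower number a stronger inhibitor:
- compound 1 `COc1cccc(/C=C/C(=O)c2c(OC)cc(OC)cc2OC)c1`: 4300 nM
- compound 2 `COc1cc(OC)c(C(=O)/C=C/c2ccccc2)c(OC)c1`: 6900 nM
- compound 3 `COc1cc(O)c(C(=O)/C=C/c2ccccc2OC)c(OC)c1`: 9200 nM

Compound 1 sits at the low end of these numbers, level within the scatter with compound 2, while compound 3 gives a higher number beyond the scatter.

Compound 4 `COc1cc(OC)c(C(=O)/C=C/c2ccc(Br)cc2)c(OC)c1` carries this change: 4-bromophenyl in place of 3-methoxyphenyl on a double-bonded chain carbon bound to a double-bonded chain carbon. For the measured compounds named here, no measured compound bears 4-bromophenyl. Going by the values given here, the one measured step that touches the leaving group is a 1.6-fold higher number from compound 1 to compound 2 (0.21 log units; within the scatter), with hydrogen in place of methoxy on an aromatic carbon. That single small step gives no ground to expect a shift beyond the scatter in this assay, in either direction. The expected step is a 1.2-fold higher number from compound 1 to compound 4 (0.07 log units; within the scatter). The estimate for compound 4 is 5000 nM, with an expected range of 2000 nM to 12000 nM.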

Compound 4, half-maximal inhibitory concentration: 6200 nM
Compound 4: middle estimate off by 1.2-fold (0.09 log units), on the low side; measured number inside the range.
By their numbers in this assay, from the lowest: compounds 1, 4, 2 and 3 (each within the scatter of the next, the first and the last beyond it).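

Measured in this assay, 4-bromophenyl in place of 3-methoxyphenyl on a double-bonded chain carbon bound to a double-bonded chain carbon gives a small change (a 1.4-fold higher number from compound 1 to compound 4 (0.16 log units; within the scatter)). Bromo in place of hydrogen on an aromatic carbon is just as small (a 1.1-fold lower number from compound 2 to compound 4 (0.05 log units; within the scatter)), so this position now shows a halogen alongside methoxy and hydrogen, all level within the scatter. No evidence on hand bears on why these numbers stay level.

From the compounds shown here alone, whether an amine or a carboxylic acid on this ring would give a step beyond the scatter remains open.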